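Replacing chloro with phenyl on the amide-bound ring

This account rests on a few compounds, and the source may have more. Where it says the series, first, only, none or still open, it means among the compounds named here.

Three compounds have been measured:
- compound 1, `CCNC(=O)CCc1cccc2c1B(O)OC2`, in a functional assay on SK-OV-3 cells (Homo sapiens) for antiproliferative activity, read by MTT assay, with a stated time of 72 h (a lower number here means a stronger inhibitor, a higher number a weaker inhibitor), gives > 100000 nM; this is a limit of the assay, not a number.
- compound 2, `O=C(CCc1cccc2c1B(O)OC2)Nc1ccc(Cl)cc1`, in this assay gives 5000 nM.
- compound 3, `O=C(CCc1cccc2c1B(O)OC2)Nc1cccc(-c2ccccc2)c1`, in this assay gives 250 nM.

All three share one core and differ only in the group on the amide nitrogen. Among the numbers shown, compound 2 stands highest, with compound 3 giving a lower number. Going by the values given here, the one measured step, an at least 20-fold lower number from compound 1 to compound 2 (1.30 log units; beyond the scatter), shows that a larger aromatic group on the amide nitrogen can move the number strongly, and the limit of > 100000 nM in this assay, at which 1 of the 3 values shown sits, marks that compound 1 reached only a limit.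

Compound 4, `O=C(CCc1cccc2c1B(O)OC2)Nc1ccc(-c2ccccc2)cc1`, is not yet measured. It differs from compound 2 as follows: phenyl in place of chloro on an aromatic carbon. Compound 3, which also carries a phenyl on that ring, gives 250 nM. Compound 4 is therefore expected to give 400 nM, within 100 nM to 2000 nM. This means an expected step of a 13-fold lower number from compound 2 to compound 4 (1.10 log units; beyond the scatter), toward a lower number.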

Compound 4, half-maximal inhibitory concentration: 48000 nM
Beside the measured number, compound 4's estimate is 120-fold (2.08 log units) below it; the measured number lies above the stated range.
By their numbers in this assay, from the lowest: compound 3; then compound 2; then compound 4. At a limit, above all of these: compound 1.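

In this assay, phenyl in place of chloro on this aromatic carbon, para to a large group, brings a 9.6-fold higher number from compound 2 to compound 4 (0.98 log units; beyond the scatter) and so a larger aromatic group on the amide nitrogen does not by itself lower the number. Compound 3 carries its phenyl at another place on that ring and gives 250 nM while compound 4 gives 48000 nM and so the presence of a phenyl alone does not set the number, and its place on the ring goes with a clear difference. Nothing shown here accounts for the rise from this change.

Still open, as far as these compounds go, is how an amine or a carboxylic acid on this same carbon would read in this assay and whether a longer chain between the amide and the shared core would move the number.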